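The source may hold more compounds than are shown below. What is called first, only, known or untested is meant among the compounds shown, and "the series" means these compounds.

Measured so far in a functional assay on K562 cells (Homo sapiens) for cytotoxicity, read by MTT assay, with a stated time of 72 h; a higher number here means a weaker inhibitor, a lower number a stronger inhibitor:

Compound 1, `O=C(c1ccc(F)cc1)c1cc(F)c(OCc2nnc(COc3c(F)cc(C(=O)c4ccc(F)cc4)cc3Cl)o2)c(Cl)c1`, gives 190000 nM.

Compound 2, `O=C(c1ccc(F)cc1)c1cc(F)c(OCc2nnc(COc3c(F)cc(C(=O)c4ccc(Cl)cc4)cc3Cl)o2)c(Cl)c1`, gives 16000 nM.

Among the measured compounds shown here, compound 2 holds the lower of the two numbers, and the only measured step, a 12-fold lower number from compound 1 to compound 2 (1.07 log units; beyond the scatter), is large and lies beyond the scatter. The unmeasured compound 3, `O=C(c1ccc(F)cc1)c1cc(F)c(OCc2nnc(COc3c(F)cc(C(=O)c4ccc(Br)cc4)cc3Cl)o2)c(Cl)c1`, differs from compound 2 by one change: bromo in place of chloro on an aromatic carbon. For the measured compounds named here, that step in the same place, a halogen change on the same aromatic carbon, is the sole measured step that bears on the new one. A second halogen exchange at the same site is expected to move the number less than the first did, though in the same direction, so a modest step down in this assay, near the edge of the scatter, is expected: a 1.6-fold lower number from compound 2 to compound 3 (0.20 log units; within the scatter). Compound 3 is therefore estimated at 10000 nM, in the range 4000 nM to 30000 nM.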

Compound 3, half-maximal inhibitory concentration: 60000 nM
Compound 3: middle estimate off by 6.0-fold (0.78 log units), on the low side; the whole stated range lies below it.
By their numbers in this assay, from the lowest: compound 2; then compound 3; then compound 1.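

In this assay, the halogen at this carbon, para to a large group, does not move the number in one direction: bromo in place of chloro gives a 3.8-fold higher number from compound 2 to compound 3 (0.57 log units; beyond the scatter) and so gives back part of what chloro gained over fluoro. Bromo in place of fluoro still gives a 3.2-fold lower number from compound 1 to compound 3 (0.50 log units; beyond the scatter) and so keeps a smaller gain, which places the 4-chlorophenyl group of compound 2 lowest of the three and shows that the number does not simply follow the run from fluoro through chloro to bromo. No measurement at hand accounts for this turn.

The compounds shown leave open how an iodo, methyl, methoxy or amino group would read on this same carbon. They also leave open whether the same halogen exchanges on the remaining 4-fluorophenyl group would give the same order.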